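The compounds below may be only part of what the source reports. "The series", "measured", "known", "first", "only" and "open" are said of these compounds alone.

Compound 1 `Cc1c(C)c2c(c(C)c1OC(=O)CCC(=O)O)CCC(C)(C(=O)NC1CC(C)(C)N([O])C(C)(C)C1)O2` is the starting point. In a toxicity assay (LMTK cells) for cytotoxicity, with Mus musculus as the target, read by MTT assay, with a stated time of 72 h (a lower number here means a stronger inhibitor, a higher number a weaker inhibitor), compound 1 reaches only the limit of the assay, > 300000 nM. Compound 2 `Cc1c(C)c2c(c(C)c1OC(=O)CCC(=O)NC1CC(C)(C)N([O])C(C)(C)C1)CCC(C)(C(=O)NC1CC(C)(C)N([O])C(C)(C)C1)O2` differs from compound 1 in one place, and in this assay compound 2 gives 133000 nM, a step of an at least 2.2-fold lower number from compound 1 to compound 2 (0.35 log units; beyond the scatter). Compound 3 `Cc1c(C)c2c(c(C)c1OC(=O)CCC(=O)O)CCC(C)(C(=O)O)O2` has not been measured; it differs from compound 1 thus: one oxygen atom in place of a group of 12 heavy atoms (9 carbon, 2 nitrogen, 1 oxygen; one six-membered non-aromatic ring with 1 hetero atom), on a carbonyl carbon. Going by the values given here, the only relevant step runs the other way, adding such a group and lowering the number, so removing one is expected to raise it or leave it at the limit, because compound 1 already sits at the limit of > 300000 nM in this assay, at which 1 of the 2 values shown sits. Compound 3 is therefore expected to give 450000 nM (range 200000 nM to 1200000 nM), a step that the limit leaves unreadable from compound 1 to compound 3.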

Compound 3, half-maximal inhibitory concentration: > 300000 nM
Compound 3: only a limit was reported; the forecaster's own chance of this, stated with the estimate: 80%; the middle value lies beyond the limit too.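

In this assay compound 3 reaches only a limit, > 300000 nM. Going by these compounds alone, compound 1 is also at a limit, and no step between compound 1 and compound 3 can be read. The compounds shown leave open whether replacing that 12-atom group with hydroxy changes the number at all.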